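The source may hold more compounds than are shown below. What is called first, only, known or untested is meant among the compounds shown, and "the series" means these compounds.

Among the compounds with values here, compound 1 `CC1(C)[C@H]2CC[C@]1(C)N(Cc1cn(-c3ccccc3C#N)nn1)C(=O)C2` is measured in a functional assay on PANC-1 cells (Homo sapiens) for inhibition, read by MTT assay, with a stated time of 24 h (on this read-out higher numbers stand for weaker inhibition and lower numbers for stronger inhibition), at 240 nM, the lowest of the two numbers so far. The nearest is compound 2 `CC1(C)[C@H]2CC[C@]1(C)N(Cc1cn(-c3ccc(Cl)cc3)nn1)C(=O)C2`, which in this assay gives 440 nM. Within the data shown here, the single measured step, a 1.8-fold higher number from compound 1 to compound 2 (0.26 log units; within the scatter), is within the scatter, so the two compounds cannot be ordered on these numbers.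

Compound 3 `Cc1cccc(-n2cc(CN3C(=O)C[C@@H]4CC[C@@]3(C)C4(C)C)nn2)c1` is not yet measured. Relative to compound 1 it differs in one place: 3-methylphenyl in place of 2-cyanophenyl on an aromatic nitrogen. Among the measured compounds shown here, the only step that bears on this change is a 1.8-fold higher number from compound 1 to compound 2 (0.26 log units; within the scatter), where a different aryl group on the same aromatic nitrogen replaced 2-cyanophenyl without moving the number beyond the scatter. 3-Methylphenyl has not itself been sampled, so the direction of any shift is open, and no step beyond the scatter is expected in either direction.

Compound 3 is therefore expected to give about 400 nM in this assay, with a range of 150 nM to 1100 nM. The expected step is a 1.7-fold higher number from compound 1 to compound 3 (0.22 log units; within the scatter), a change estimated to remain within the scatter.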

Compound 3, half-maximal inhibitory concentration: 240 nM
The estimate for compound 3 lay 1.7-fold (0.22 log units) above the measured number, and the stated range covers the measured number.
By their numbers in this assay, from the lowest: compounds 1, 3 and 2 (each within the scatter of the next).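

In this assay, 3-methylphenyl in place of 2-cyanophenyl on the aromatic nitrogen gives no change at the digits printed from compound 1 to compound 3 (within the scatter) and so the nitrile, with the one hydrogen-bond acceptor counted in the leaving group, can be exchanged for a methyl-bearing phenyl with no step beyond the scatter. Set against the chlorinated aryl group, the same 3-methylphenyl gives a 1.8-fold lower number from compound 2 to compound 3 (0.26 log units; within the scatter) and the three aryl groups now sampled at this position, 2-cyanophenyl, 4-chlorophenyl and 3-methylphenyl, cannot be ordered on these numbers. No measurement is at hand that would explain this flat result.

Still open, from the compounds shown here alone, is whether any group on this nitrogen moves the number beyond the scatter: a phenyl bearing an amine or a carboxylic acid, a benzyl group, a pyridine ring or a longer alkyl chain would each test the position beyond simple substituted phenyl groups. The three compounds also share one core and one linking methylene, so they say nothing about how much of the reading depends on those parts rather than on the aryl group.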